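This account rests on a few compounds, and the source may have more. Where it says the series, first, only, none or still open, it means among the compounds named here.

Measured compounds:
compound 1 `COC(=O)/C=C/c1cccc(N(Cc2ccc(/C=C/c3c(Cl)cccc3Cl)cc2)C(=O)C(C)C)c1`, in an assay on isolated protein with Bile acid receptor (Homo sapiens) as the target (a higher number here means that more compound is needed for the effect, a lower number that less compound is needed), compound 1 gives 195 nM
compound 2 `COC(=O)/C=C/c1cccc(N(Cc2ccc(-c3ccc(SC)cc3)cc2)C(=O)C(C)C)c1`, in this assay compound 2 gives 51 nM
compound 3 `COC(=O)/C=C/c1cccc(N(Cc2ccc(-c3cccc(C)c3)cc2)C(=O)C(C)C)c1`, in this assay compound 3 gives 163 nM

Compound 3 stands second highest of the three numbers; its value and that of compound 1 lie within the scatter of each other, and only compound 2 is set apart from it, as a 3.2-fold higher number from compound 2 to compound 3 (0.50 log units; beyond the scatter) shows. Compound 4 `COC(=O)/C=C/c1cccc(N(Cc2ccc(-c3ccc(N(C)C)cc3)cc2)C(=O)C(C)C)c1` differs from compound 3 in one place: 4-(dimethylamino)phenyl in place of 3-methylphenyl on an aromatic carbon. Going by the values given here, two measured steps bear on this change. The step of a 1.2-fold lower number from compound 1 to compound 3 (0.08 log units; within the scatter) shows that exchanging the group on that carbon can leave the number unchanged, whereas a 3.2-fold higher number from compound 2 to compound 3 (0.50 log units; beyond the scatter) shows that a phenyl carrying a group at its far position can lower the number by a modest amount. Among the compounds with values here, since compound 4 again carries a substituted phenyl at that position, a modest lowering of the number is expected, though smaller than the one seen with compound 2 cannot be ruled out. Compound 4 is therefore estimated at 75 nM, with a range from 25 nM to 250 nM, a step of a 2.2-fold lower number from compound 3 to compound 4 (0.34 log units; beyond the scatter) that is expected rather than known.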

Compound 4, half-maximal effective concentration: 57 nM
Estimate against measurement, compound 4: 1.3-fold (0.12 log units) above, within the range that was stated.
By their numbers in this assay, from the lowest: compounds 2 and 4 (each within the scatter of the next); then compounds 3 and 1 (each within the scatter of the next).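

In this assay, the step of a 2.9-fold lower number from compound 3 to compound 4 (0.46 log units; beyond the scatter) shows that 4-(dimethylamino)phenyl on this aromatic carbon, para to a large group, gives a lower number than 3-methylphenyl, and the step of a 3.4-fold lower number from compound 1 to compound 4 (0.53 log units; beyond the scatter) sets it apart from 2-(2,6-dichlorophenyl)ethenyl as well. Going by these compounds alone, the step of a 1.1-fold higher number from compound 2 to compound 4 (0.05 log units; within the scatter) shows that dimethylamino and methylsulfanyl cannot be told apart here, so 4-(methylsulfanyl)phenyl is no longer the only group at this place to give a low number. Nothing available explains these differences.

As far as these compounds go, whether an unsubstituted phenyl, 4-methoxyphenyl or 4-aminophenyl would give a number like that of compound 4 remains open. From the compounds shown here alone, it is equally open whether moving the dimethylamino group to the position held by methyl in compound 3 would keep that number.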